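Cyano to methoxy on the phenyl: notes on compound 4

The source may hold more compounds than are shown below. What is called first, only, known or untested is meant among the compounds shown, and "the series" means these compounds.

The series shares one core and varies the group on a six-membered aromatic ring of carbon only. Compound 1 `O=[N+]([O-])c1ccc(-c2csc(N3N=C(c4ccc(N5CCCCC5)cc4)CC3c3ccc(Cl)cc3)n2)cc1` carries a nitro there; in a functional assay on MCF7 cells (Homo sapiens) for antiproliferative activity, read by MTT assay, with a stated time of 72 h (on this read-out lower numbers stand for stronger inhibition and higher numbers for weaker inhibition), compound 1 gives only a limit, > 100000 nM. Compound 2 `Fc1ccc(-c2csc(N3N=C(c4ccc(N5CCCCC5)cc4)CC3c3ccc(Cl)cc3)n2)cc1` carries fluoro and in this assay compound 2 gives 23100 nM. Compound 3 `N#Cc1ccc(-c2csc(N3N=C(c4ccc(N5CCCCC5)cc4)CC3c3ccc(Cl)cc3)n2)cc1` carries cyano and in this assay compound 3 gives 9760 nM. Among the two numbers shown compound 3 stands lowest, with compound 2 nearest; the step of a 2.4-fold lower number from compound 2 to compound 3 (0.37 log units; beyond the scatter) is modest, an at least 10-fold lower number from compound 1 to compound 3 (1.01 log units; beyond the scatter) is large, and an at least 4.3-fold lower number from compound 1 to compound 2 (0.63 log units; beyond the scatter) is at least modest.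

Compound 4 `COc1ccc(-c2csc(N3N=C(c4ccc(N5CCCCC5)cc4)CC3c3ccc(Cl)cc3)n2)cc1` differs from compound 3 in one place: methoxy in place of cyano on an aromatic carbon. Among the compounds with values here, no measured step exchanges a methoxy, so the three steps bear only indirectly: they show that cyano gives the lowest number and that each exchange of this group moved the read-out beyond the scatter. A move back toward the number of compound 2 is expected, so a modest rise in this assay is estimated, a 2.3-fold higher number from compound 3 to compound 4 (0.35 log units; beyond the scatter). Compound 4 is therefore expected to give about 22000 nM, within 7000 nM to 70000 nM.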

Compound 4, half-maximal inhibitory concentration: > 100000 nM
Compound 4: only a limit was reported; the forecaster's own chance of this, stated with the estimate: 10%; middle value at least 4.5-fold (0.65 log units) from the limit.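

In this assay compound 4 returns only a limit, the second such result at this position: the limit of > 100000 nM in this assay, at which 2 of the 4 values shown sit. The exchange of methoxy for cyano is a large step, an at least 10-fold higher number from compound 3 to compound 4 (1.01 log units; beyond the scatter), and the exchange of methoxy for fluoro is at least a modest one, an at least 4.3-fold higher number from compound 2 to compound 4 (0.63 log units; beyond the scatter). Cyano and methoxy have the same count of heavy atoms and of hydrogen-bond acceptors, so these counts do not separate a measurable number from a limit here, and among the four compounds only the 4-cyanophenyl and fluoro-bearing members give measurable numbers.

The step between the nitro and methoxy compounds cannot be read, since both values are limits, so these two groups cannot be placed in order. Still open, as far as these compounds go, is whether a hydroxyl, an amine or a carboxylic acid at this place would give a measurable number, and whether a chloro or a longer alkoxy chain would stay nearer to compound 2 or to compound 4.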